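A few compounds are considered here, and "the series" means these few. Any claim that something is new, unique, unknown or untested is made for them only; others in the source may bear on it.

Of the compounds shown here, three from this series have been measured in an assay on isolated protein with Bile acid receptor (Homo sapiens) as the target; on this read-out lower numbers stand for an effect already at smaller amounts and higher numbers for an effect only at larger amounts of compound. Compound 2 `COC(=O)/C=C/c1cccc(N(Cc2ccc(/C=C/c3c(F)cccc3F)cc2)C(=O)C(C)C)c1` gives 108 nM, the lowest of the three numbers. Compound 3 `COC(=O)/C=C/c1cccc(N(Cc2ccc(/C=C/c3ccccn3)cc2)C(=O)C2CCCCC2)c1` gives 309 nM, and compound 1 `COC(=O)/C=C/c1cccc(N(Cc2ccc(/C=C/c3cc(C(F)(F)F)cc(C(F)(F)F)c3)cc2)C(=O)C(C)C)c1` gives 1950 nM. Compound 2 stands apart from both: the gap to compound 3 and the wider gap to compound 1 each lie beyond the usual scatter, so compound 2 is the strongest binder of the set.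

Compound 4 `COC(=O)/C=C/c1cccc(N(Cc2ccc(/C=C/c3scnc3C)cc2)C(=O)C(C)C)c1` has not been measured. It differs from compound 2 in one place: 4-methyl-1,3-thiazol-5-yl in place of 2,6-difluorophenyl on a double-bonded chain carbon bound to a double-bonded chain carbon. For the measured compounds named here, no pair of measured compounds differs in exactly this way, so no measured step shows what such a swap does. Going by the values given here, the only other measured compound with a different ring on the ethenyl chain, compound 3, also carries a different acyl group, so its value cannot be read as the effect of a ring change alone.

With nothing measured to lean on, the step from compound 2 to compound 4 in this assay is expected to be a modest loss, a 2.3-fold higher number from compound 2 to compound 4 (0.36 log units; beyond the scatter), rather than a gain. Compound 4 is accordingly estimated at 250 nM, with a range from 80 nM to 800 nM.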

Compound 4, half-maximal effective concentration: 228 nM
The estimate for compound 4 lay 1.1-fold (0.04 log units) above the measured number; measured number inside the range.
By their numbers in this assay, from the lowest: compound 2; then compounds 4 and 3 (each within the scatter of the next); then compound 1.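

For the compounds shown here, the step of a 2.1-fold higher number from compound 2 to compound 4 (0.32 log units; beyond the scatter) is the only one-place change that can be read in this assay, and it gives a size for a ring change on the ethenyl chain with the acyl group held constant, which compound 3 could not provide. Replacing 2,6-difluorophenyl, a six-membered aromatic ring of carbon only, with 4-methyl-1,3-thiazol-5-yl, a five-membered aromatic ring with 2 hetero atoms and 2 hydrogen-bond acceptors, gives only a modest loss, so this place tolerates a ring of quite different size and make-up, and compound 4 still reads 228 nM. No measurement on hand accounts for the loss that accompanies this swap.

The compounds shown leave open which feature of the new ring sets the size of the step, as a single swap cannot separate the methyl group from the ring itself. A thiazol-5-yl ring without the methyl group or an unsubstituted phenyl ring, each with the acyl group of compound 2 and compound 4, would address that question.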